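Fluoro Swapped for Methyl on the Shared Core

The compounds below may be only part of what the source reports. "The series", "measured", "known", "first", "only" and "open" are said of these compounds alone.

Within the data shown here, in an ADME assay on Vero cells (Chlorocebus sabaeus) for cytotoxicity (on this read-out higher numbers stand for lower toxicity in this test and lower numbers for higher toxicity in this test), compound 1 `Nc1ncc(F)c2c1ncn2[C@@H]1C=C(CO)[C@@H](O)[C@H]1O` gives 35700 nM as the lower of two numbers so far, and compound 2 `Nc1ncc(F)c2c1ncn2[C@@H]1C=C(CCO)[C@@H](O)[C@H]1O` gives 109000 nM as the higher. Compound 3 `Cc1cnc(N)c2ncn([C@@H]3C=C(CO)[C@@H](O)[C@H]3O)c12` differs from compound 1 at another place, with methyl in place of fluoro on an aromatic carbon in all. Among the measured compounds shown here, no measured step covers this swap, so a 3.1-fold higher number from compound 1 to compound 2 (0.48 log units; beyond the scatter) is only a rough guide to size, made on a chain and not on the aromatic ring. The expected change is a 1.1-fold higher number from compound 1 to compound 3 (0.05 log units; within the scatter) in no firm direction, so nothing beyond the scatter is expected. For compound 3 the estimate is 40000 nM with an expected range from 13000 nM to 120000 nM in this test.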

Compound 3, half-maximal cytotoxic concentration: 228000 nM
Compound 3: middle estimate off by 5.7-fold (0.76 log units), on the low side; measured number outside the range, above it.
By their numbers in this assay, from the lowest: compound 1; then compound 2; then compound 3.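

In this assay, the aromatic carbon para to an amino group proves to be a place where a single swap counts: methyl in place of fluoro gives a 6.4-fold higher number from compound 1 to compound 3 (0.81 log units; beyond the scatter), a move toward lower toxicity in this test. Until now, only a change on the chain had shown a step. Nothing measured here explains why this swap has this effect. On these data alone, whether chloro or ethyl on this carbon would move the number the same way stays open, as does whether methyl in place of fluoro would act alike on compound 2.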